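The compounds below may be only part of what the source reports. "The series", "measured", "known", "first", "only" and "open" are said of these compounds alone.

Measured so far:
compound 1 `CC(=O)c1ccc(OCCCCOc2cccc(C(=O)O)c2C)c(C)c1O` — 79.2%
compound 2 `CCCC(=O)c1ccc(OCCCCOc2ccc(F)c(C(=O)O)c2)c(C)c1O` — 87.5%

In an assay on HEK293 cells for positive allosteric modulation of metabotropic glutamate receptor 2 (Rattus norvegicus), read by thallium flux, with a stated time of 2.5 min (on this read-out lower numbers stand for smaller maximal responses and higher numbers for larger maximal responses), compound 1 gives 79.2%, the lower of the two numbers; the nearest is compound 2 with 87.5%, a gap that stays within the scatter, so the two are not ordered. Compound 3 `Cc1c(OCCCCOc2ccc(C(=O)C(C)C)c(O)c2C)cccc1C(=O)O` is not yet measured. Against compound 1 it shows (isopropyl in place of methyl on a carbonyl carbon). Among the compounds with values here, no step between measured compounds bears on this change, so the expected step of a number 2.8 percentage points higher from compound 1 to compound 3 (within the scatter) in this assay is small, if any, and not beyond the scatter. For compound 3 the estimate is 82%, within 65% to 100%.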

Compound 3, largest response reached (reported as percent of maximum), in percent of the reference or control that the assay uses: 66.9%
Compound 3: the middle estimate sits 15.1 percentage points above what was measured; low and high end bracket the measured number.
By their numbers in this assay, from the lowest: compound 3; then compounds 1 and 2 (each within the scatter of the next).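

In this assay, isopropyl in place of methyl on a carbonyl carbon gives a number 12.3 percentage points lower from compound 1 to compound 3 (beyond the scatter), so the group at this place can shift the maximal response. Compound 2 differs from compound 1 in more than one place and does not bear on this change. Nothing measured here accounts for the step.

Only methyl and isopropyl can be compared at this place, so one step gives no trend with group size. On these data alone, whether ethyl or tert-butyl on the same carbonyl carbon would extend this step remains open.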